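This account rests on a few compounds, and the source may have more. Where it says the series, first, only, none or still open, it means among the compounds named here.

Compound 1 `N#CC1=C(NCC(=O)N2CCOCC2)N(c2ccccc2)C(=O)N2CCCCC(N3CCCC3)C12` gives 73.5%
Compound 2 `CCOC(=O)C(=O)NC1=C(C#N)C2C(N3CCCC3)CCCCN2C(=O)N1c1ccccc1` gives 91.5%
Compound 3 `N#CC1=C(/N=C/c2ccc([N+](=O)[O-])cc2)N(c2ccccc2)C(=O)N2CCCCC(N3CCCC3)C12` gives 91.7%

These three numbers come from a functional assay on the whole organism (strain albino) for inhibition, with Rattus norvegicus as the target, read by paw edema, with stated times of 1 h and 3 h, at a dose of 20 mmol/kg by the intraperitoneal route; on this read-out higher numbers stand for a stronger effect at the one dose given and lower numbers for a weaker effect. On them compound 1 stands lowest of the three; compound 2 is nearest to it and compound 3 furthest, and the steps to both lie beyond the scatter.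

Compound 4 `N#CC1=C(NC(=O)c2ccccc2O)N(c2ccccc2)C(=O)N2CCCCC(N3CCCC3)C12` is not yet measured. It differs from compound 1 in one place: (2-hydroxyphenyl)carbonyl in place of ((morpholin-4-yl)carbonyl)methyl on an amine nitrogen. Among the measured compounds shown here, two measured steps bear on this change. The step of a number 18 percentage points higher from compound 1 to compound 2 (beyond the scatter) also replaces the ((morpholin-4-yl)carbonyl)methyl group on the amine nitrogen with a carbonyl-bearing group, and the step of a number 18.2 percentage points higher from compound 1 to compound 3 (beyond the scatter) brings in a six-membered aromatic ring of carbon only on the shared core. Both steps were modest rises. The change to compound 4 combines a carbonyl on the amine nitrogen with such an aromatic ring, so a modest rise of a similar size is expected, a number 12.5 percentage points higher from compound 1 to compound 4 (beyond the scatter). Compound 4 is therefore estimated at 86% in this assay, within a range from 72% to 97%.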

Compound 4, a percentage reported as inhibition, in the whole organism at one dose (the size of the read-out at that dose, not a potency): 65.4%
The estimate for compound 4 lay 20.6 percentage points above the measured number; measured number below the stated range.
By their numbers in this assay, from the lowest: compounds 4 and 1 (each within the scatter of the next); then compounds 2 and 3 (each within the scatter of the next).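

In this assay, a carbonyl and an aromatic ring on the amine nitrogen do not together bring a rise, since (2-hydroxyphenyl)carbonyl in place of ((morpholin-4-yl)carbonyl)methyl gives a number 8.1 percentage points lower from compound 1 to compound 4 (within the scatter). What the carbonyl carries clearly counts: 2-hydroxyphenyl in place of ethoxycarbonyl on the carbonyl carbon gives a number 26.1 percentage points lower from compound 2 to compound 4 (beyond the scatter). An aromatic ring alone therefore does not account for the high number of compound 3, as the change of the whole group on the double-bonded ring carbon gives a number 26.3 percentage points lower from compound 3 to compound 4 (beyond the scatter).

Nothing available here bears on the cause of these steps. From the compounds shown here alone, whether the hydroxy group or the ring itself sets the number remains open, and a plain phenylcarbonyl group on the same nitrogen would help to separate the two.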